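This account rests on a few compounds, and the source may have more. Where it says the series, first, only, none or still open, it means among the compounds named here.

Compound 1 `CCOC(=O)c1c(-c2ccccc2C)[nH]c2cc(OC)ccc2c1=O` gives > 100000 nM
Compound 2 `CCOC(=O)c1c(-c2ccc(OC)cc2)[nH]c2cccc(OC)c2c1=O` gives > 100000 nM
Compound 3 `CCOC(=O)c1c(-c2ccc(Cl)cc2)[nH]c2cccc(OC)c2c1=O` gives > 100000 nM

In a physicochemical assay for solubility, in phosphate buffer, at pH 7.4 (a lower number here means a less soluble compound, a higher number a more soluble compound), compound 1 gives > 100000 nM as a limit and not a number. All three compounds share this position, namely the limit of > 100000 nM in this assay, at which 3 of the 3 values shown sit, and none of them has a readable number.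

Compound 4 `CCOC(=O)c1c(-c2cccc(OC)c2)[nH]c2cc(OC)ccc2c1=O` carries 3-methoxyphenyl in place of 2-methylphenyl on an aromatic carbon next to the ring nitrogen, and 3-methoxyphenyl in place of 2-methylphenyl on an aromatic carbon counts the difference. For the measured compounds named here, the one measured step, a step that the two limits leave unreadable from compound 2 to compound 3 with chloro in place of methoxy, gives no size to carry over, so no shift in either direction beyond the usual scatter is expected in this assay for this change. The expected step is a number no higher from compound 1 to compound 4 (the limit leaves the size open) by this estimate. For compound 4 the estimate is 100000 nM with an expected range from 50000 nM to 200000 nM and a good chance of another limit.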

Compound 4, solubility: > 100000 nM
Compound 4: no number, only a limit; the forecaster's own chance of this, stated with the estimate: 80%; the middle value sits exactly at the limit.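

With 3-methoxyphenyl in place of 2-methylphenyl, no step can be read from compound 1 to compound 4, because both stand at a limit and not a number: the limit of > 100000 nM in this assay, at which 4 of the 4 values shown sit.

How far beyond that limit each of these compounds lies stays open.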